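Acylguanidine series: methoxy for methyl in compound 4

This account rests on a few compounds, and the source may have more. Where it says the series, first, only, none or still open, it means among the compounds named here.

Compound 1 `Cc1cc(Br)c(S(C)(=O)=O)cc1C(=O)N=C(N)N` gives 12 nM in a functional assay for inhibition of sodium/hydrogen exchanger (Oryctolagus cuniculus); a lower number here means a stronger inhibitor, a higher number a weaker inhibitor. Compound 2 `Cc1cc(Sc2ccncc2)c(S(C)(=O)=O)cc1C(=O)N=C(N)N` gives 13 nM in this assay, and compound 3 `Cc1cc(N2CCC(N)CC2)c(S(C)(=O)=O)cc1C(=O)N=C(N)N` gives 9.8 nM in this assay. The three steps that join them, a 1.1-fold higher number from compound 1 to compound 2 (0.03 log units; within the scatter), a 1.2-fold lower number from compound 1 to compound 3 (0.09 log units; within the scatter) and a 1.3-fold lower number from compound 2 to compound 3 (0.12 log units; within the scatter), all stay within the scatter, so the three numbers read as one level. Compound 3 holds the lowest of the three numbers, but its gaps to compound 1 and to compound 2 are within the scatter, and no order among the three is claimed.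

Compound 4 `COc1cc(N2CCC(N)CC2)c(S(C)(=O)=O)cc1C(=O)N=C(N)N` is not yet measured. It differs from compound 3 in one place: methoxy in place of methyl on an aromatic carbon. Among the compounds with values here, none of the measured steps varies this position; all three exchange the group that stands as 4-aminopiperidin-1-yl in compound 3 and compound 4, and each of them lay within the scatter. Within the data shown here, no measured step therefore bears directly on the change, and the expectation for this assay rests on the shared core alone: no step beyond the scatter is expected in either direction, with a wider range than usual for want of a matched step. The step from compound 3 to compound 4 is expected to be a 1.2-fold higher number from compound 3 to compound 4 (0.09 log units; within the scatter). Compound 4 is accordingly estimated at 12 nM in this assay, between 4 nM and 40 nM.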

Compound 4, half-maximal inhibitory concentration: 73 nM
Estimate against measurement, compound 4: 6.1-fold (0.78 log units) below; measured number above the stated range.
By their numbers in this assay, from the lowest: compounds 3, 1 and 2 (each within the scatter of the next); then compound 4.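

In this assay, the site ortho to a group of 6 heavy atoms and para to a methylsulfonyl group proves sensitive to substitution: methoxy in place of methyl gives a 7.4-fold higher number from compound 3 to compound 4 (0.87 log units; beyond the scatter). Within the data shown here, all the earlier steps exchanged the group meta to this site, among bromo, (pyridin-4-yl)sulfanyl and 4-aminopiperidin-1-yl, and all stayed within the scatter, so this is the first step to go beyond it, even though the entering group differs from the leaving one only by an oxygen, which brings a hydrogen-bond acceptor. No evidence at hand bears on why the number rises here.

Going by these compounds, with only methyl and methoxy at this site, it remains open whether the rise goes with the oxygen itself or with any departure from methyl, and a chloro, ethyl or hydroxy group there would help to separate those readings. Methoxy also appears only alongside 4-aminopiperidin-1-yl, so whether the same step holds with bromo or (pyridin-4-yl)sulfanyl in that place remains untested in the compounds shown.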